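The source may report more compounds than this note shows. Statements on the series, on what has been measured and on what is new or still open speak of the compounds shown alone.

Three compounds share one core and differ only in the group carried on the amide-type nitrogen. Compound 1 `COc1cc(NC(C)CCCNC(=O)Nc2ccc(C(F)(F)F)cc2)c2ncccc2c1` gives 1900 nM in a functional assay on MCF7 cells (Homo sapiens) for inhibition, read by MTT assay, with a stated time of 72 h; a lower number here means a stronger inhibitor, a higher number a weaker inhibitor. Compound 2 `COc1cc(NC(C)CCCNC(=O)Nc2ccc(O)cc2)c2ncccc2c1` gives 5200 nM in this assay, and compound 3 `COc1cc(NC(C)CCCNC(=O)Nc2cccc(Cl)c2)c2ncccc2c1` gives 11000 nM, the highest of the three numbers, set apart from the others by a 5.8-fold higher number from compound 1 to compound 3 (0.76 log units; beyond the scatter) and a 2.1-fold higher number from compound 2 to compound 3 (0.33 log units; beyond the scatter). Compound 4 `COc1cc(NC(C)CCCNC(=O)Nc2cccc(C(F)(F)F)c2)c2ncccc2c1` differs from compound 3 in one place: trifluoromethyl in place of chloro on an aromatic carbon. Within the data shown here, no measured step swaps chloro for trifluoromethyl at a fixed place; the closest is a 5.8-fold higher number from compound 1 to compound 3 (0.76 log units; beyond the scatter), which alters both group and place, while a 2.7-fold higher number from compound 1 to compound 2 (0.44 log units; beyond the scatter) shows trifluoromethyl giving the lowest number of the set. A modest fall in the number is therefore expected, a 2.2-fold lower number from compound 3 to compound 4 (0.34 log units; beyond the scatter). Compound 4 is estimated at 5000 nM, between 1500 nM and 16000 nM.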

Compound 4, half-maximal inhibitory concentration: 3300 nM
For compound 4 the middle estimate is 1.5-fold (0.18 log units) above the measured one, within the range that was stated.
By their numbers in this assay, from the lowest: compounds 1, 4 and 2 (each within the scatter of the next, the first and the last beyond it); then compound 3.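

With a 3.3-fold lower number from compound 3 to compound 4 (0.52 log units; beyond the scatter) in this assay, the change from chloro to trifluoromethyl, meta to a large group, is now seen at one fixed place, and the step lies beyond the scatter. By contrast, a 1.7-fold higher number from compound 1 to compound 4 (0.24 log units; within the scatter) and a 1.6-fold lower number from compound 2 to compound 4 (0.20 log units; within the scatter) both stay within the scatter, so 3-(trifluoromethyl)phenyl cannot be separated from 4-(trifluoromethyl)phenyl or 4-hydroxyphenyl here. No measurement shown explains why the swap changes the number. The compounds shown leave open how an amine or a carboxylic acid at this same place would read in this assay.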